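Cyclohexylmethyl Gives Way to 1,1-Dioxothian-4-yl

The compounds below may be only part of what the source reports. "The series", "measured", "known", "first", "only" and "open" are said of these compounds alone.

Compound 1 `c1ccc2c(c1)CN[C@@H](CN(CCCCNCC1CCCCC1)[C@H]1CCCc3cccnc31)C2` shows the highest number of three related compounds tested in a functional assay on cells for antagonist activity at C-X-C chemokine receptor type 4 (Homo sapiens), read by fluorescence and calcium flux, with stated times of 25 min and 90 s; on this read-out lower numbers stand for stronger inhibition and higher numbers for weaker inhibition: compound 1 gives 158 nM, whereas compound 2 `c1ccc2c(c1)CN[C@@H](CN(CCCCNCC1CCOCC1)[C@H]1CCCc3cccnc31)C2` gives 52.9 nM and compound 3 `c1ccc2c(c1)CN[C@@H](CN(CCCCNC1CCNCC1)[C@H]1CCCc3cccnc31)C2` gives 63.4 nM. The new compound 4 `O=S1(=O)CCC(NCCCCN(C[C@H]2Cc3ccccc3CN2)[C@H]2CCCc3cccnc32)CC1` differs from compound 1 by 1,1-dioxothian-4-yl in place of cyclohexylmethyl on an amine nitrogen. For the measured compounds named here, two measured steps bear on this change, a 3.0-fold lower number from compound 1 to compound 2 (0.48 log units; beyond the scatter) and a 2.5-fold lower number from compound 1 to compound 3 (0.40 log units; beyond the scatter), each replacing all or part of the carbon-only ring with a six-membered ring carrying a hetero atom. Both gave lower numbers of similar size in this assay, so a modest step down is expected here too, a 2.6-fold lower number from compound 1 to compound 4 (0.42 log units; beyond the scatter). Compound 4 is therefore estimated at 60 nM, with a likely range from 25 nM to 150 nM.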

Compound 4, half-maximal inhibitory concentration: 45.5 nM
Beside the measured number, compound 4's estimate is 1.3-fold (0.12 log units) above it; the measured number falls inside the stated range.
By their numbers in this assay, from the lowest: compounds 4, 2 and 3 (each within the scatter of the next); then compound 1.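

A third ring with a hetero atom, this one holding sulfur and two oxygens, also gives a 3.5-fold lower number from compound 1 to compound 4 (0.54 log units; beyond the scatter) in this assay. Against the other two such rings, the result is a 1.4-fold lower number from compound 3 to compound 4 (0.14 log units; within the scatter) and a 1.2-fold lower number from compound 2 to compound 4 (0.07 log units; within the scatter), so these three groups cannot be told apart at this amine nitrogen. No evidence here explains the result.

Compounds 3 and 4 also lose the methylene link of compound 1, so the hetero atom and the link remain confounded. A plain cyclohexyl ring set directly on the amine nitrogen would separate the two.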